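Adding a second (pyrrolidin-1-yl)methyl group to compound 2

A few compounds are considered here, and "the series" means these few. Any claim that something is new, unique, unknown or untested is made for them only; others in the source may bear on it.

Compound 1 `CCN(CC)Cc1ccc2c(c1O)-c1ccc(cc1O)CCc1ccc(O)c(c1)Oc1ccc(cc1)CC2` gives 5740 nM
Compound 2 `Oc1ccc2cc1Oc1ccc(cc1)CCc1ccc(CN3CCCC3)c(O)c1-c1ccc(cc1O)CC2` gives 2260 nM

In a functional assay on A549 cells (Homo sapiens) for antiproliferative activity, read by MTT assay, with a stated time of 48 h (a lower number here means a stronger inhibitor, a higher number a weaker inhibitor), compound 2 sits at 2260 nM and holds the lower of the two numbers. Compound 3 `Oc1cc2ccc1-c1c(ccc(CN3CCCC3)c1O)CCc1ccc(cc1)Oc1cc(cc(CN3CCCC3)c1O)CC2` has a (pyrrolidin-1-yl)methyl in place of hydrogen on an aromatic carbon. Among the measured compounds shown here, the only measured step (a 2.5-fold lower number from compound 1 to compound 2 (0.40 log units; beyond the scatter)) exchanged diethylamino for pyrrolidin-1-yl and added no new group, so it guides only loosely. A modest move toward a lower number is therefore expected (a 1.3-fold lower number from compound 2 to compound 3 (0.10 log units; within the scatter)), though a move the other way remains possible. For compound 3 the estimate is 1800 nM (expected range 700 nM to 4500 nM).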

Compound 3, half-maximal inhibitory concentration: 990 nM
For compound 3 the middle estimate is 1.8-fold (0.26 log units) above the measured one; measured number inside the range.
By their numbers in this assay, from the lowest: compound 3; then compound 2; then compound 1.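

In this assay, a (pyrrolidin-1-yl)methyl on the aromatic carbon ortho to a hydroxy group gives a 2.3-fold lower number from compound 2 to compound 3 (0.36 log units; beyond the scatter) and a step beyond the usual scatter. This position therefore tolerates a second amine-bearing group, whereas the earlier step only exchanged one amine for another. No measurement here explains the fall. As far as these compounds go, it remains open whether the pyrrolidine ring itself matters at this position, or whether a (morpholin-4-yl)methyl group or a plain methyl would give a similar number.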